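The source may hold more compounds than are shown below. What is called first, only, known or untested is meant among the compounds shown, and "the series" means these compounds.

In a functional assay on Jurkat cells (Homo sapiens) for cytotoxicity, read by MTT assay, with a stated time of 24 h (a higher number here means that more compound is needed for the effect, a lower number that less compound is needed), three compounds sharing one core have been measured. Compound 1 `CCOC(=O)c1cc([Se]Cc2ccccc2)c2cc(OC)ccc2n1` gives 20800 nM and compound 2 `CCCCC#Cc1cc(C(=O)OCC)nc2ccc(OC)cc12` gives 15900 nM, and a 1.3-fold lower number from compound 1 to compound 2 (0.12 log units; within the scatter) shows that these two are not distinguishable. Compound 3 `CCOC(=O)c1cc([Se]c2ccccc2)c2cc(OC)ccc2n1` stands highest of the three at 102000 nM, so more of it is needed for the effect. The steps to it are a 4.9-fold higher number from compound 1 to compound 3 (0.69 log units; beyond the scatter) and a 6.4-fold higher number from compound 2 to compound 3 (0.81 log units; beyond the scatter).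

Compound 4 `COc1ccc2nc(-c3c(C)cccc3C)cc([Se]c3ccccc3)c2c1` keeps the phenyl on selenium but changes another place, on an aromatic carbon next to the ring nitrogen, where 2,6-dimethylphenyl stands in place of ethoxycarbonyl: 2,6-dimethylphenyl in place of ethoxycarbonyl on an aromatic carbon.

For the measured compounds named here, no measured step touches this place, since all three alter a different group of the core. They show only how far a single change has moved the number in this small series, from nothing beyond the scatter to a modest shift. The direction is therefore a weak guess, resting on compound 3 lying at the top of the series with 102000 nM. A modest move towards a lower number in this assay seems most likely, though no change at all remains possible. The estimated step is a 2.6-fold lower number from compound 3 to compound 4 (0.41 log units; beyond the scatter). The expected value for compound 4 is 40000 nM, with an estimated range of 10000 nM to 150000 nM.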

Compound 4, half-maximal effective concentration: 26900 nM
Beside the measured number, compound 4's estimate is 1.5-fold (0.17 log units) above it; measured number inside the range.
By their numbers in this assay, from the lowest: compounds 2, 1 and 4 (each within the scatter of the next); then compound 3.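

In this assay, the place on the aromatic carbon next to the ring nitrogen proves able to shift the number: swapping ethoxycarbonyl for 2,6-dimethylphenyl gives a 3.8-fold lower number from compound 3 to compound 4 (0.58 log units; beyond the scatter). The earlier compounds shown here all carried ethoxycarbonyl here and differed only in the group at another place on the core, so they gave no view of this position. The ester is not needed to keep cytotoxicity in this assay, since its replacement, which has a six-membered aromatic ring and no hydrogen-bond acceptors, gives a lower number rather than a higher one, but nothing available explains the shift or separates the gain of the ring from the loss of the two acceptors.

Going by these compounds, it remains open whether the same swap would move the number in the same direction with benzyl on the selenium, as in compound 1, rather than phenyl as in compound 3. On these data alone, it is also open how a plain phenyl without the two methyl groups, a carboxylic acid or an amide would behave at this place.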